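Compound 3: 4-methoxyphenyl in place of 3-methoxyphenyl

A few compounds are considered here, and "the series" means these few. Any claim that something is new, unique, unknown or untested is made for them only; others in the source may bear on it.

Two compounds have so far been followed in an ADME assay on the whole organism (Rattus norvegicus, strain Lewis) for metabolic stability, read by LC-MS, with a stated time of 72 h, at a dose of 2 mg/kg by the oral route; on this read-out higher numbers stand for a longer-lived compound and lower numbers for a shorter-lived compound. In this assay compound 1 `N[C@]1(CO)CC[C@H](c2ccc3c(c2)CC[C@@H](CCc2ccccc2)C3)C1` gives > 75 h, and this is a limit of the assay and not a number. Within the data shown here, compound 2 `COc1cccc(CC2CCc3cc([C@H]4CC[C@](N)(CO)C4)ccc3C2)c1` gives 15 h, which makes it the only compound here with an actual number.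

Compound 3 `COc1ccc(CC2CCc3cc([C@H]4CC[C@](N)(CO)C4)ccc3C2)cc1` has not yet been measured. It differs from compound 2 in a single place, with 4-methoxyphenyl in place of 3-methoxyphenyl on a saturated chain carbon bound to a saturated ring carbon. The two compounds have the same atoms, joined differently. Among the measured compounds shown here, no measured pair shows what a change of this kind does in this assay, so the expectation rests on compound 2 and its 15 h alone. The expected step of no change at the digits printed from compound 2 to compound 3 (within the scatter) is no larger than the usual scatter of repeated measurements, and no direction is expected. Compound 3 is therefore estimated at 15 h, with an expected range from 7 h to 32 h.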

Compound 3, half-life: 64 h
Compound 3: the middle estimate sits 4.3-fold (0.63 log units) below what was measured; the measured number lies above the stated range.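

Putting 4-methoxyphenyl in place of 3-methoxyphenyl, on a saturated chain carbon bound to a saturated ring carbon, gives a 4.3-fold higher number from compound 2 to compound 3 (0.63 log units; beyond the scatter) in this assay. Among these compounds, this is the first measured pair that differs in one place, and it shows that this position is sensitive to the change: two groups with the same atoms and the same counts of donors and acceptors give values that lie beyond the usual scatter of each other. The read-out also has an upper end that matters for any further rise in this series: the limit of > 75 h in this assay, at which 1 of the 3 values shown sits.

As far as these compounds go, what remains open is whether the step belongs to the methoxy group itself, since a single pair cannot separate it from anything else about the 4-substituted ring, and the result gives no reason for the step. Nothing shown tells how this assay would respond at this place to an unsubstituted phenyl, a fluorophenyl or an ethoxyphenyl, or whether the same exchange would give a similar step on the longer phenylethyl chain of compound 1.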